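Anilide series: methoxy in place of hydrogen on compound 1

This account rests on a few compounds, and the source may have more. Where it says the series, first, only, none or still open, it means among the compounds named here.

Measured so far in an assay on isolated protein for inhibition of Ectonucleotide pyrophosphatase/phosphodiesterase family member 1 (Homo sapiens), tested at 10 uM; a lower number here means less inhibition, a higher number more inhibition at the concentration tested (going by the name of the read-out):
compound 1 `O=C(CSc1nc2cccnc2[nH]1)Nc1ccccc1` — 30%
compound 2 `O=C(CSc1nc2cccnc2[nH]1)Nc1ccccc1Cl` — 19%
compound 3 `CN(C)c1ccc(NC(=O)CSc2nc3cccnc3[nH]2)cc1` — 23%

Compound 1 stands highest of the three numbers in this assay. Compound 3 is nearest: a number 7 percentage points lower from compound 1 to compound 3 (within the scatter). Compound 2 is furthest: a number 11 percentage points lower from compound 1 to compound 2 (beyond the scatter). Among the compounds with values here, only the step to compound 2 lies beyond the scatter; compound 1 and compound 3 cannot be ordered on these numbers.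

Compound 4 `COc1cccc(NC(=O)CSc2nc3cccnc3[nH]2)c1` is the next member. Its difference from compound 1 is methoxy in place of hydrogen on an aromatic carbon. The two measured changes from compound 1 also add a group to the same aromatic ring, and both run downward, one modestly beyond the scatter and one within it. Neither introduces methoxy, and neither sits meta to a large group, so they bear on the step to compound 4 only as a rough guide: no substituent so far has raised the number.

The expectation is therefore a small downward step, likely within the scatter: a number 6 percentage points lower from compound 1 to compound 4 (within the scatter). Compound 4 is estimated at 24%, with a range from 12% to 36% in this assay.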

Compound 4, a percentage reported as inhibition, at one concentration (the size of the read-out at that concentration, not a potency): 30%
Compound 4: the middle estimate sits 6 percentage points below what was measured; the measured number falls inside the stated range.
By their numbers in this assay, from the lowest: compounds 2, 3, 1 and 4 (each within the scatter of the next, the first and the last beyond it).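

In this assay, methoxy on an aromatic carbon, meta to a large group, gives no change at the digits printed from compound 1 to compound 4 (within the scatter), so this position accepts this group with no detectable cost or gain in the read-out at the single concentration tested. Within the data shown here, compound 4 is the first of the substituted anilides whose step from compound 1 shows no difference at all, and the downward run of the two earlier steps does not extend to this change; across the three substituents, none raises the number beyond the scatter, and only compound 2 moves it beyond the scatter, downward. The series offers no independent measurement that would account for this step, so the result stands as an observation only.

Open is whether the flat step belongs to methoxy or to the position, since the compounds shown do not place methoxy on another carbon of the ring or put a different group, such as an amine, a carboxylic acid or a longer alkoxy chain, meta to a large group. Also open, going by these compounds, is whether any single addition to this ring can raise the number beyond the scatter from compound 1.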